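From a five-membered ring to an open oxime ether

The source may report more compounds than this note shows. Statements on the series, on what has been measured and on what is new or still open speak of the compounds shown alone.

The compounds share a core built from an aniline linked through a short chain to an imidazoline, with a small group on the aromatic ring. Compound 1 `c1coc(-c2ccccc2NCC2=NCCN2)c1` carries a furan-2-yl and in a functional assay for activation of Alpha-1B adrenergic receptor (Homo sapiens), read by calcium flux (on this read-out lower numbers stand for an effect already at smaller amounts and higher numbers for an effect only at larger amounts of compound), compound 1 gives 6.31 nM. Compound 2 `Cc1nc(-c2ccccc2NCC2=NCCN2)cs1` carries a 2-methyl-1,3-thiazol-4-yl and compound 2 gives 69.2 nM, so an 11-fold higher number from compound 1 to compound 2 (1.04 log units; beyond the scatter). Compound 3 `c1ccc(-c2cnoc2)c(NCC2=NCCN2)c1` carries a 1,2-oxazol-4-yl. For compound 3 only a limit is known, < 100000 nM, because of the limit of < 100000 nM in this assay, at which 1 of the 3 values shown sits. Hence a step that the limit leaves unreadable from compound 1 to compound 3 and a step that the limit leaves unreadable from compound 2 to compound 3.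

Compound 4 `CO/N=C/c1ccccc1NCC1=NCCN1` is not yet measured. a group of 4 heavy atoms (2 carbon, 1 nitrogen, 1 oxygen; no ring) in place of a group of 5 heavy atoms (3 carbon, 1 nitrogen, 1 oxygen; one five-membered aromatic ring with 2 hetero atoms), on an aromatic carbon

For the measured compounds named here, only one readable step exists, and it concerns two ring groups rather than the open group that enters here, so the expected size of the step cannot be read from it; the limit on compound 3 leaves its direction open as well. Compound 4 is therefore estimated at 1000 nM, between 50 nM and 20000 nM, which would mean an expected step that the limit leaves unreadable from compound 3 to compound 4.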

Compound 4, half-maximal effective concentration: < 5020 nM
Compound 4: no number, only a limit; the forecaster's own chance of this, stated with the estimate: 15%; the middle value is on the limit's open side.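

In this assay, for the compounds shown here, compound 4 gives < 5020 nM, which is a limit and not a number, so no step from compound 1, compound 2 or compound 3 to compound 4 can be read. From the compounds shown here alone, how the open group of compound 4 compares with the ring groups of those three compounds stays open.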